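Acetyl for Methyl on a Weakly Active Fused Core

The source may hold more compounds than are shown below. What is called first, only, known or untested is meant among the compounds shown, and "the series" means these compounds.

Three compounds share a piperidine ether bearing a difluorophenyl group, an isopropylamino group and a fused two-ring core, and differ in how that core is built. Compound 1 `Cc1cc2nc(NC(C)C)c(N3CCC(Oc4ccc(F)cc4F)CC3)nc2cn1` and compound 2 `Cc1cc2nc(N3CCC(Oc4ccc(F)cc4F)CC3)c(NC(C)C)nc2cn1` carry an aromatic core; compound 3 `CC(C)Nc1nc2c(nc1N1CCC(Oc3ccc(F)cc3F)CC1)C=CN(C)C2` has a core in which one ring is non-aromatic and carries a methyl on a ring nitrogen. In a functional assay on CHO-K1 cells for agonist activity at G-protein coupled receptor 6 (Homo sapiens), read by TR-FRET and cAMP accumulation, with a stated time of 20 h (on this read-out higher numbers stand for an effect only at larger amounts of compound and lower numbers for an effect already at smaller amounts), compound 1 gives 16000 nM, compound 2 gives 61000 nM and compound 3 gives 89000 nM. All three act only at large amounts. The numbers for compound 3 and compound 2 lie within the usual scatter of each other, so nothing separates them; the gap from compound 3 to compound 1 lies beyond the scatter, so compound 1 acts at smaller amounts than compound 3.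

Compound 4 `CC(=O)N1C=Cc2nc(N3CCC(Oc4ccc(F)cc4F)CC3)c(NC(C)C)nc2C1` is a single change from compound 3: acetyl in place of methyl on an amine nitrogen in a ring. Among the measured compounds shown here, no measured pair in this set shows what such a change does, so there is no step to lean on. Given that, the expected step from compound 3 to compound 4 is a 1.1-fold lower number from compound 3 to compound 4 (0.05 log units; within the scatter), which would stay within the scatter. Compound 4 is therefore expected to give about 80000 nM, with a likely range from 25000 nM to 250000 nM.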

Compound 4, half-maximal effective concentration: 34000 nM
Beside the measured number, compound 4's estimate is 2.4-fold (0.37 log units) above it, and the stated range covers the measured number.
By their numbers in this assay, from the lowest: compound 1; then compounds 4, 2 and 3 (each within the scatter of the next, the first and the last beyond it).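

In this assay, among the compounds shown here, acetyl in place of methyl on this amine nitrogen in a ring gives a 2.6-fold lower number from compound 3 to compound 4 (0.42 log units; beyond the scatter), the first change in one place that can be read in this set. It shows that the group on this ring nitrogen can move the number beyond the usual scatter, and that the move from methyl to acetyl, with its added heavy atoms and hydrogen-bond acceptor, goes toward an effect at smaller amounts, although compound 4 still acts only at large amounts. Nothing measured here explains why the number falls.

As far as these compounds go, with a single step at this position, it stays open whether the carbonyl or the extra size of the acetyl matters, and a longer acyl chain such as propanoyl, a methylsulfonyl group or a plain hydrogen on this nitrogen would help to separate the two. Also unanswered is whether acetyl in place of methyl would give a step of similar size and direction on a different core, or whether it holds only for the core shared by compound 3 and compound 4.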